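The source may hold more compounds than are shown below. What is called first, only, known or untested is meant among the compounds shown, and "the series" means these compounds.

Measured in a functional assay on QGY-7703 cells (Homo sapiens) for cytotoxicity, read by MTT assay, with a stated time of 24 h; a lower number here means a stronger inhibitor, a higher number a weaker inhibitor:
- compound 1 `O=C1/C(=C/c2cccnc2)CN(S(=O)(=O)c2ccc(C(F)(F)F)cc2)C/C1=C\c1ccccc1F`: 4500 nM
- compound 2 `Cc1ccc(S(=O)(=O)N2C/C(=C\c3ccncc3)C(=O)/C(=C/c3ccccc3F)C2)cc1`: > 20000 nM
- compound 3 `O=C1/C(=C/c2ccncc2)CN(S(=O)(=O)c2ccc([N+](=O)[O-])cc2)C/C1=C\c1ccccc1F`: 8800 nM

The entry for compound 2, > 20000 nM, is a limit and not a number. Within the data shown here, only two true numbers are therefore available, and compound 3 at 8800 nM lies within the scatter of compound 1 at 4500 nM.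

Compound 4 `O=C1/C(=C/c2ccncc2)CN(S(=O)(=O)c2ccc(C(F)(F)F)cc2)C/C1=C\c1ccccc1F` has not yet been measured. It has trifluoromethyl in place of nitro on an aromatic carbon, para to a large group (trifluoromethyl in place of nitro on an aromatic carbon), which turns 4-nitrophenyl into 4-(trifluoromethyl)phenyl.

Among the measured compounds shown here, the one measured single-place step is an at least 2.2-fold lower number from compound 2 to compound 3 (0.35 log units; beyond the scatter), with nitro in place of methyl. It shows that this place can shift the number, but its size is bounded on one side only, and it does not involve trifluoromethyl. Compound 1 carries 4-(trifluoromethyl)phenyl but differs elsewhere from compound 4, and compound 1 gives 4500 nM.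

The expected change is a 1.4-fold lower number from compound 3 to compound 4 (0.13 log units; within the scatter), which is estimated to stay within the scatter. For compound 4 the expected value is 6500 nM, with an estimated range of 2500 nM to 16000 nM.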

Compound 4, half-maximal inhibitory concentration: 9500 nM
Compound 4: middle estimate off by 1.5-fold (0.16 log units), on the low side, within the range that was stated.
By their numbers in this assay, from the lowest: compounds 1, 3 and 4 (each within the scatter of the next, the first and the last beyond it). At a limit, above all of these: compound 2.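

At the aromatic carbon para to a large group, trifluoromethyl and nitro cannot be told apart in this assay (a 1.1-fold higher number from compound 3 to compound 4 (0.03 log units; within the scatter)). Among these compounds, the pyridine also matters, and this is the first single-place reading of that change: with 4-(trifluoromethyl)phenyl held constant, pyridin-4-yl in place of pyridin-3-yl gives a difference beyond the scatter (a 2.1-fold higher number from compound 1 to compound 4 (0.32 log units; beyond the scatter)). The step from methyl to trifluoromethyl can be read in one direction only (an at least 2.1-fold lower number from compound 2 to compound 4 (0.32 log units; beyond the scatter)), as compound 2 carries a limit and not a number: the limit of > 20000 nM in this assay, at which 1 of the 4 values shown sits.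

On these data alone, it remains open whether a different group at this aromatic carbon, such as an amine or a carboxylic acid, would separate from trifluoromethyl and nitro. As far as these compounds go, it is also open whether the difference between pyridin-4-yl and pyridin-3-yl holds with nitro or methyl at that carbon.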